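Dropping the carbamate: a hydroxy pyrrolidine analogue

The source may hold more compounds than are shown below. What is called first, only, known or untested is meant among the compounds shown, and "the series" means these compounds.

Measured so far:
Compound 1 `COc1ccc(-c2c(C)nc3c(N4CC[C@@H](NC(=O)Oc5cccc(C)c5)C4)cc(C)nn23)cc1OC`: in an ADME assay on microsomes from liver (Mus musculus) for metabolic stability, read by LC-MS, with NADPH named in the record, with a stated time of 60 min, tested at 1 uM, in the absence of a further agent (a lower number here means that less of the compound is left, a higher number that more of the compound is left), compound 1 gives > 95%, a limit of the assay rather than a number.
Compound 2 `COc1ccc(-c2c(C)nc3c(N4CC[C@@H](NS(=O)(=O)c5ccc(C(C)=O)cc5)C4)cc(C)nn23)cc1OC`: in this assay compound 2 gives > 95%, also a limit.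

Compound 1 therefore stands at the upper limit, where both values shown sit (the limit of > 95% in this assay, at which 2 of the 2 values shown sit). Going by the values given here, the one measured step, a step that the two limits leave unreadable from compound 1 to compound 2, exchanges a (4-acetylphenyl)sulfonyl for a (3-methylphenoxy)carbonyl on the amine nitrogen; because both ends sit at the limit (the limit of > 95% in this assay, at which 2 of the 2 values shown sit), its size cannot be read. Compound 3 `COc1ccc(-c2c(C)nc3c(N4CC[C@@H](O)C4)cc(C)nn23)cc1OC` differs from compound 1 in another way: hydroxy in place of ((3-methylphenoxy)carbonyl)amino on a saturated ring carbon. No measured step touches this exact change, so nothing shown gives a direction for it. Among the compounds with values here, the shared core is kept, and the only measured step on this ring carbon ends at the limit. Compound 3 is thus expected to give about 85%, with a likely range from 55% to 99%. The expected step is then a number at least 10 percentage points lower from compound 1 to compound 3 (that floor lies within the scatter), which may not exceed the usual scatter.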

Compound 3, percent of the compound remaining: > 95%
Compound 3 gave a limit, no number; the forecaster's own chance of this, stated with the estimate: 45%; at least 10 percentage points between middle value and limit.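

In this assay compound 3 gives > 95%, a limit of the assay and not a number. The step from compound 1 to compound 3 cannot be read, because both compounds sit at the same limit: the limit of > 95% in this assay, at which 3 of the 3 values shown sit.

Going by these compounds, whether the groups on this saturated ring carbon differ at all in how much of the compound is left stays open.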